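The source may hold more compounds than are shown below. What is called first, only, known or untested is meant among the compounds shown, and "the series" means these compounds.

Measured in a functional assay on SW-620 cells (Homo sapiens) for cytotoxicity; a higher number here means a weaker inhibitor of growth, a lower number a stronger inhibitor of growth:
- Compound 1 `COc1ccc(C2=C(c3ccc(SC)cc3)CC3CCCN3C2=O)cc1Br`: 5000 nM
- Compound 2 `COc1ccc(C2=C(c3ccc(SC)cc3)CC3CCCN3C2=O)cc1C`: 500 nM
- Compound 3 `CSc1ccc(C2=C(c3ccc(F)c(F)c3)C(=O)N3CCCC3C2)cc1`: 200 nM

Compound 3 has the lowest number of the three, at 200 nM. The smaller of the two steps reaching it is a 2.5-fold lower number from compound 2 to compound 3 (0.40 log units; beyond the scatter), and the larger is a 25-fold lower number from compound 1 to compound 3 (1.40 log units; beyond the scatter).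

Compound 4 `CSc1ccc(C2=C(c3ccc(F)c(C)c3)C(=O)N3CCCC3C2)cc1` is still to be measured in this assay. The change is methyl in place of fluoro on an aromatic carbon, ortho to a fluoro group, so that 3,4-difluorophenyl becomes 4-fluoro-3-methylphenyl.

Within the data shown here, no measured step makes this exact swap, so the evidence is indirect. Among the measured compounds shown here, the one step that brings in methyl is a 10-fold lower number from compound 1 to compound 2 (1.00 log units; beyond the scatter), but methyl replaces bromo there, not fluoro, and on a different aryl group. The step of a 2.5-fold lower number from compound 2 to compound 3 (0.40 log units; beyond the scatter) is modest and favours 3,4-difluorophenyl over a methyl-bearing aryl group, although it also removes a methoxy group. Together these point to a small rise in the number, with the direction uncertain. The expected step is a 1.5-fold higher number from compound 3 to compound 4 (0.18 log units; within the scatter).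

Compound 4 is estimated at 300 nM, with an expected range of 100 nM to 900 nM.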

Compound 4, concentration for 50% growth inhibition: 600 nM
Beside the measured number, compound 4's estimate is 2.0-fold (0.30 log units) below it; the range from low to high includes it.
By their numbers in this assay, from the lowest: compound 3; then compounds 2 and 4 (each within the scatter of the next); then compound 1.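

In this assay, among these compounds, a 3.0-fold higher number from compound 3 to compound 4 (0.48 log units; beyond the scatter) gives the first direct reading of methyl in place of fluoro on this aromatic carbon, ortho to a fluoro group, with everything else in the molecule held fixed, and the 3,4-difluorophenyl group keeps the lower number. With the methyl kept, fluoro in place of methoxy gives a 1.2-fold higher number from compound 2 to compound 4 (0.08 log units; within the scatter), so the two groups are not told apart on this methyl-bearing aryl group, and an 8.3-fold lower number from compound 1 to compound 4 (0.92 log units; beyond the scatter) leaves the 3-bromo-4-methoxyphenyl group of compound 1 with the highest number in the set. Nothing on hand accounts for any of these steps.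

The compounds shown leave open how a chloro, a hydroxyl or an amine would read on this same aromatic carbon, and so whether fluoro is the best group there or only better than methyl. Also open, on these data alone, is whether the step from fluoro to methyl keeps its size with a methoxy group on the same aryl ring, or with the methylthio group on the other aryl ring exchanged for a sulfone.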